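This account rests on a few compounds, and the source may have more. Where it says the series, first, only, none or still open, it means among the compounds named here.

In a functional assay on MDA-MB-231 cells (Homo sapiens) for cytotoxicity, read by MTT assay, with a stated time of 48 h (a lower number here means a stronger inhibitor, a higher number a weaker inhibitor), compound 1 (`Fc1cccc(-c2nc(Nc3ccccc3)c3cc(F)ccc3n2)c1`) gives 47800 nM. Compound 2 (`Fc1cccc(-c2nc(Nc3ccc(Cl)cc3)c3cc(F)ccc3n2)c1`) is reported only as a limit, > 50000 nM. Compound 3 (`Fc1cccc(-c2nc(Nc3ccccc3Br)c3cc(F)ccc3n2)c1`) is also reported only as a limit, > 50000 nM. That places compound 3 on (the limit of > 50000 nM in this assay, at which 2 of the 3 values shown sit), so it has no exact number from which to count.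

Compound 4 (`Cc1cccc(Nc2nc(-c3cccc(F)c3)nc3ccc(F)cc23)c1`) carries 3-methylphenyl in place of 2-bromophenyl on a nitrogen on an aromatic ring.

Within the data shown here, no measured step introduces 3-methylphenyl, so only indirect evidence bears on this change. The two steps that start from compound 1 are an at least 1.0-fold higher number from compound 1 to compound 2 (0.01 log units; that floor lies within the scatter) and an at least 1.0-fold higher number from compound 1 to compound 3 (0.01 log units; that floor lies within the scatter), and each is only a floor within the scatter. The remaining step, a step that the two limits leave unreadable from compound 2 to compound 3, cannot be sized. On this evidence, no step beyond the scatter is expected in this assay, and no direction can be firmly expected.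

The estimated step is an at least 1.1-fold lower number from compound 3 to compound 4 (0.04 log units; that floor lies within the scatter). Compound 4 could again be reported only as a limit. For compound 4, the expected value is 45000 nM, with an estimated range of 20000 nM to 70000 nM.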

Compound 4, half-maximal inhibitory concentration: > 50000 nM
Compound 4 gave a limit, no number; the forecaster's own chance of this, stated with the estimate: 50%; middle value at least 1.1-fold (0.04 log units) away from the limit.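

In this assay compound 4 is again reported only as a limit, > 50000 nM. On the nitrogen, 3-methylphenyl now joins 4-chlorophenyl and 2-bromophenyl in giving no exact number, so a carbon-only substituent behaves here as the chloro and bromo ones do, and the values collect at one point: the limit of > 50000 nM in this assay, at which 3 of the 4 values shown sit. Among these compounds, the one readable step is an at least 1.0-fold higher number from compound 1 to compound 4 (0.01 log units; that floor lies within the scatter); the steps among the three limits cannot be read.

As far as these compounds go, only compound 1 has an exact number, so the size of any effect at this position remains unknown. From the compounds shown here alone, whether an amine or a carboxylic acid on this phenyl ring would give an exact number in this assay stays open.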